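The source may report more compounds than this note shows. Statements on the series, on what has been measured and on what is new or still open speak of the compounds shown alone.

an ADME assay on microsomes from liver (Rattus norvegicus) for metabolic stability (a lower number here means that the compound disappears faster, a higher number that the compound lasts longer), is the measure throughout. Within the data shown here, compound 2 `CC(C)C(Nc1nccs1)c1ccc(-c2ccc3cccc(F)c3c2)[nH]c1=O` gives 0.07 h in this assay, and that is the only plain number among the three values shown. Compound 1 `CC(C)C(c1ncc[nH]1)c1ccc(-c2ccc3cccc(F)c3c2)[nH]c1=O` reaches only the limit < 0.0667 h in this assay. Compound 3 `CCn1ncc2c(F)cc(-c3ccc(C(CC)(CC)c4ncn(C)n4)c(=O)[nH]3)cc21` sits at the limit > 3 h in this assay. Among the measured compounds shown here, the single measured step, an at least 1.0-fold higher number from compound 1 to compound 2 (0.02 log units; that floor lies within the scatter), stays within the scatter.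

Compound 4 `CC(C)C(/C=C1\CCNC1=O)c1ccc(-c2ccc3cccc(F)c3c2)[nH]c1=O` has not yet been measured. It differs from compound 2 in one place: a group of 7 heavy atoms (5 carbon, 1 nitrogen, 1 oxygen; one five-membered non-aromatic ring with 1 hetero atom) in place of a group of 6 heavy atoms (3 carbon, 2 nitrogen, 1 sulfur; one five-membered aromatic ring with 2 hetero atoms), on a saturated chain carbon bound to an aromatic carbon and a saturated chain carbon. For the measured compounds named here, no measured step covers an exchange of this kind; the only step recorded puts (1,3-thiazol-2-yl)amino in place of 1H-imidazol-2-yl, and it changes nothing beyond the scatter. With so little to go on, the expected step is a 1.4-fold higher number from compound 2 to compound 4 (0.15 log units; within the scatter), small and in no firm direction. Compound 4 is accordingly estimated at 0.1 h, with a likely range from 0.03 h to 0.4 h.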

Compound 4, half-life: 0.345 h
Beside the measured number, compound 4's estimate is 3.5-fold (0.54 log units) below it; measured number inside the range.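

At the saturated chain carbon bound to an aromatic carbon and a saturated chain carbon, the group can shift the half-life measurably in this assay: the group with the five-membered non-aromatic ring, in place of (1,3-thiazol-2-yl)amino, gives a 4.9-fold higher number from compound 2 to compound 4 (0.69 log units; beyond the scatter). The same group in place of 1H-imidazol-2-yl gives an at least 5.1-fold higher number from compound 1 to compound 4 (0.71 log units; beyond the scatter), so two different aromatic-ring groups both give way to it with a step beyond the scatter, unlike the earlier exchange between those two groups. Compound 1 has a limit and not a plain number, so its step is only a floor: the limit of < 0.0667 h in this assay, at which 1 of the 4 values shown sits.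

The compounds shown leave open which part of the entering group goes with the longer half-life: its ring, its carbonyl or its double bonds outside aromatic rings. They also leave open how a simple amine, a carboxylic acid or a longer chain at this place would behave in this assay.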